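Oxygen to sulfur on the seven-membered ring amide

A few compounds are considered here, and "the series" means these few. Any claim that something is new, unique, unknown or untested is made for them only; others in the source may bear on it.

Within the data shown here, the two compounds measured so far share a core and differ in the group on the saturated ring carbon. Compound 1 `CO[C@@H]1C[C@@H](C(=S)N2CCC(N3CCCC3)CC2)N(C(=O)NCc2ccc(C(=O)N3CCCCc4sccc43)cc2Cl)C1` gives 480 nM in an assay on isolated protein with Oxytocin receptor (Homo sapiens) as the target; on this read-out higher numbers stand for an effect only at larger amounts of compound and lower numbers for an effect already at smaller amounts. Compound 2 `CO[C@@H]1C[C@@H](C(=O)N2CCCN(C)CC2)N(C(=O)NCc2ccc(C(=O)N3CCCCc4sccc43)cc2Cl)C1` gives 2800 nM in this assay, the highest number of the two, and its nearest neighbour, compound 1, lies at a lower number beyond the usual scatter. Compound 1 and compound 2 differ in two places at once, so their gap cannot be assigned to a single change.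

Compound 3 `CO[C@@H]1C[C@@H](C(=S)N2CCCN(C)CC2)N(C(=O)NCc2ccc(C(=O)N3CCCCc4sccc43)cc2Cl)C1` has not yet been measured. It differs from compound 2 in one place: a group of 10 heavy atoms (7 carbon, 2 nitrogen, 1 sulfur; one seven-membered non-aromatic ring with 2 hetero atoms) in place of a group of 10 heavy atoms (7 carbon, 2 nitrogen, 1 oxygen; one seven-membered non-aromatic ring with 2 hetero atoms), on a saturated ring carbon. Among the measured compounds shown here, no step between measured compounds isolates this exchange of carbonyl for thiocarbonyl. Compound 1 carries a thiocarbonyl at the same place, together with a different amine, and its lower number 480 nM is the only hint on offer.

In this assay compound 3 is therefore expected to move modestly toward a lower number, a step of a 2.2-fold lower number from compound 2 to compound 3 (0.33 log units; beyond the scatter), and an estimate of 1300 nM is given, with a range from 400 nM to 4000 nM.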

Compound 3, half-maximal effective concentration: 430 nM
Compound 3: the middle estimate sits 3.0-fold (0.48 log units) above what was measured, within the range that was stated.
By their numbers in this assay, from the lowest: compounds 3 and 1 (each within the scatter of the next); then compound 2.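

With the 4-methyl-1,4-diazepan-1-yl amine held fixed, the exchange of carbonyl for thiocarbonyl on the saturated ring carbon can now be read as a single change, and in this assay it gives a 6.5-fold lower number from compound 2 to compound 3 (0.81 log units; beyond the scatter). On the thiocarbonyl carbon, 4-methyl-1,4-diazepan-1-yl in place of 4-(pyrrolidin-1-yl)piperidin-1-yl gives a 1.1-fold lower number from compound 1 to compound 3 (0.05 log units; within the scatter), so this read-out does not separate these two amines when the thiocarbonyl is present. Nothing available explains either step.

Among these compounds, whether the exchange of carbonyl for thiocarbonyl has a step of similar size with the 4-(pyrrolidin-1-yl)piperidin-1-yl amine would take the carbonyl counterpart of compound 1 to tell, since the one readable step rests on a single amine. From the compounds shown here alone, it also remains open whether the insensitivity to the amine on the thiocarbonyl carbon extends to a morpholine ring, which has an oxygen in place of the basic ring nitrogen, or to a simple open-chain dimethylamino group.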